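A few compounds are considered here, and "the series" means these few. Any claim that something is new, unique, unknown or untested is made for them only; others in the source may bear on it.

Among the compounds with values here, in a functional assay on HUVEC cells (Homo sapiens) for inhibition (a higher number here means a weaker inhibitor, a lower number a stronger inhibitor), compound 1 (`CN(c1ccc(NC(=O)Oc2ccccc2)cc1)c1ccnc(Nc2cccc(CS(C)(=O)=O)c2)n1`) gives 224 nM and compound 2 (`CN(c1ccc(NC(=N)Nc2ccccc2)cc1)c1ccnc(Nc2cccc(CS(C)(=O)=O)c2)n1`) gives 596 nM, the higher of the two numbers so far. Compound 3 (`CCNC(=O)Nc1ccc(N(C)c2ccnc(Nc3cccc(CS(C)(=O)=O)c3)n2)cc1`) is next: a group of 5 heavy atoms (3 carbon, 1 nitrogen, 1 oxygen; no ring) in place of a group of 9 heavy atoms (7 carbon, 2 nitrogen; one six-membered aromatic ring of carbon only), on a nitrogen on an aromatic ring. Within the data shown here, the only measured step, a 2.7-fold higher number from compound 1 to compound 2 (0.42 log units; beyond the scatter), is modest and exchanges two groups of equal heavy-atom count, so it is a loose guide to this larger change. Compound 3 shares a carbonyl with compound 1 at 224 nM, so a modest move to a lower number is expected in this assay. The expected step is a 2.1-fold lower number from compound 2 to compound 3 (0.33 log units; beyond the scatter). For compound 3 the estimated value is 280 nM, with an expected range of 70 nM to 1000 nM.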

Compound 3, half-maximal inhibitory concentration: 3 nM
Compound 3: middle estimate off by 93-fold (1.97 log units), on the high side; measured number below the stated range.
By their numbers in this assay, from the lowest: compound 3; then compound 1; then compound 2.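

In this assay the group on a nitrogen on an aromatic ring can move the number much further than the step between compound 1 and compound 2 suggested: ethylcarbamoyl gives (a 200-fold lower number from compound 2 to compound 3 (2.30 log units; beyond the scatter)). On the carbonyl carbon, ethylamino in place of phenoxy gives (a 75-fold lower number from compound 1 to compound 3 (1.87 log units; beyond the scatter)), so the lowest number of the three comes with the group that has no ring. Nothing measured here accounts for this gain. Still open, on these data alone, is how much depends on the ethyl chain itself: methylamino, a longer chain such as propylamino, or a cyclic amine on the same carbonyl carbon would test this.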